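Thiosemicarbazide series: hydrazone arylidene variation and cytotoxicity

A few compounds are considered here, and "the series" means these few. Any claim that something is new, unique, unknown or untested is made for them only; others in the source may bear on it.

Compound 1 `CC1=CC[C@@H]([C@@](C)(O)CCCC(C)(C)NC(=S)NN)CC1` is the free thiosemicarbazide of the series. In a functional assay on UACC-62 cells (Homo sapiens) for cytotoxicity, read by sulforhodamine B assay (a lower number here means that less compound is tolerated, a higher number that more compound is tolerated), compound 1 gives > 100000 nM, which is a limit of the assay rather than a number. Compound 4 `CC1=CC[C@@H]([C@@](C)(O)CCCC(C)(C)NC(=S)N/N=C(/C)c2ccccc2)CC1` differs from it by a group of 9 heavy atoms (8 carbon, 1 nitrogen; one six-membered aromatic ring of carbon only) in place of one nitrogen atom, on an amide-type nitrogen. The closest measured precedent is compound 2 `COc1ccc(/C=N\NC(=S)NC(C)(C)CCC[C@](C)(O)[C@@H]2CC=C(C)CC2)cc1`, in which a methoxyphenyl methylidene group sits at the same place; in this assay compound 2 gives 48500 nM, so the change is an at least 2.0-fold lower number from compound 1 to compound 2 (0.31 log units; beyond the scatter). Compound 3 `CC1=CC[C@@H]([C@@](C)(O)CCCC(C)(C)NC(=S)N/N=C\c2ccc([N+](=O)[O-])cc2)CC1` carries the nitrophenyl analogue. In this assay compound 3 gives > 100000 nM, which is again a limit. The step of an at least 2.0-fold higher number from compound 2 to compound 3 (0.31 log units; beyond the scatter) shows that the arylidene substituent matters, with two of the three values resting at the limit of > 100000 nM in this assay, at which 2 of the 3 values shown sit. For compound 4 a step no larger than that seen for compound 2 is expected, an at least 1.4-fold lower number from compound 1 to compound 4 (0.15 log units; that floor lies within the scatter), and the result may also stop at the limit. Compound 4 is therefore estimated at 70000 nM, within 30000 nM to 200000 nM.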

Compound 4, concentration lethal to 50% of the cells: > 100000 nM
Compound 4 ended at the assay's limit; the forecaster's own chance of this, stated with the estimate: 50%; at least 1.4-fold (0.15 log units) between middle value and limit.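

The group of 9 heavy atoms on the amide-type nitrogen does not bring the result off the limit, so a six-membered aromatic ring of carbon only at this place is not enough on its own to give a readable value: the limit of > 100000 nM in this assay, at which 3 of the 4 values shown sit.

Replacing the group of 10 heavy atoms with this one gives an at least 2.0-fold higher number from compound 2 to compound 4 (0.31 log units; beyond the scatter), which leaves the methoxy-bearing group as the only one shown here with a value that is a number. The step between the two compounds at the limit with the free thiosemicarbazide as start cannot be read, as both ends are limits.

The compounds shown do not separate the methoxy group from the other differences between the two groups. From the compounds shown here alone, how an amine on the aromatic ring, or a longer chain in place of that ring, would read in this assay stays open.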